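The source may report more compounds than this note shows. Statements on the series, on what has been measured and on what is new or still open speak of the compounds shown alone.

Compound 2 `COc1cc(C2=NN(C(C)=O)C(c3cc(Cl)cc(Cl)c3)O2)cc(OC)c1OC` gives the highest number of the three compounds measured in a functional assay on PC-3 cells (Homo sapiens) for antiproliferative activity, read by MTT assay, tested at 5 uM; a lower number here means a weaker effect, a higher number a stronger effect of the compound at the concentration tested: compound 2 reaches 93.9%. Its nearest neighbour, compound 3 `COc1cc(C(=O)N/N=C/c2cccc(F)c2)cc(OC)c1OC`, gives 64.1% in this assay, a gap beyond the scatter. Furthest away stands compound 1 `COc1ccc(/C=N/NC(=O)c2cc(OC)c(OC)c(OC)c2)c(OC)c1`, which in this assay gives 22.2%. Compound 4 `COc1ccc(C2OC(c3cc(OC)c(OC)c(OC)c3)=NN2C(C)=O)c(OC)c1` has not yet been measured. It differs from compound 2 in one place: 2,4-dimethoxyphenyl in place of 3,5-dichlorophenyl on a saturated ring carbon. Going by the values given here, no measured pair shows this change directly, but compound 1, which also carries a 2,4-dimethoxyphenyl group on a different core, gives only 22.2%, so the expected step of a number 33.9 percentage points lower from compound 2 to compound 4 (beyond the scatter) is a decrease beyond the scatter. Compound 4 is therefore estimated to reach 60% in this assay, within a range from 30% to 85%.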

Compound 4, a percentage reported as inhibition, at one concentration (the size of the read-out at that concentration, not a potency): 92%
Beside the measured number, compound 4's estimate is 32 percentage points below it, outside the stated range (above it).
By their numbers in this assay, from the lowest: compound 1; then compound 3; then compounds 4 and 2 (each within the scatter of the next).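

In this assay, going by these compounds alone, 2,4-dimethoxyphenyl in place of 3,5-dichlorophenyl on the saturated ring carbon gives a number 1.9 percentage points lower from compound 2 to compound 4 (within the scatter), the first direct reading at this position. With the shared core held fixed, the read-out thus stays in place although the entering group brings hydrogen-bond acceptors that the leaving group lacks. No measurement shown explains why these two groups read alike.

The compounds shown leave open what a carboxylic acid or an amine on this phenyl ring would give. Going by these compounds, because the read-out comes from one concentration and is not a potency, whether compound 2 and compound 4 would also match at other concentrations stays open too.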